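The source may hold more compounds than are shown below. What is called first, only, known or untested is meant among the compounds shown, and "the series" means these compounds.

Measured compounds in this set:

- compound 1, `O=C(OC1CCC(CN2CCN(c3cc(=O)c4cc(C(F)(F)F)cc([N+](=O)[O-])c4s3)CC2)CC1)C1CCCCC1`: 0.0967 h
- compound 2, `CS(=O)(=O)NC1CCC(CN2CCN(c3cc(=O)c4cc(C(F)(F)F)cc([N+](=O)[O-])c4s3)CC2)CC1`: > 1.55 h
- compound 3, `COc1ccc(C(=O)OC2CCC(CN3CCN(c4cc(=O)c5cc(C(F)(F)F)cc([N+](=O)[O-])c5s4)CC3)CC2)cc1`: 0.165 h

In an ADME assay on cells (Hepatocyte, Homo sapiens) for metabolic stability (on this read-out lower numbers stand for a shorter-lived compound and higher numbers for a longer-lived compound), compound 1 gives 0.0967 h. In this assay compound 3 gives 0.165 h, the higher of the two numbers, though the step of a 1.7-fold higher number from compound 1 to compound 3 (0.23 log units; within the scatter) lies within the scatter, so the two cannot be ordered. For compound 2 the result in this assay is a limit rather than a number, > 1.55 h, as noted in the limit of > 1.55 h in this assay, at which 1 of the 3 values shown sits. The steps of an at least 16-fold higher number from compound 1 to compound 2 (1.20 log units; beyond the scatter) and an at least 9.3-fold lower number from compound 2 to compound 3 (0.97 log units; beyond the scatter) are the only ones beyond the scatter, and both concern the exchange of methanesulfonamido against a carbonyl-bearing oxygen on the saturated ring carbon, not the group on the carbonyl carbon itself.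

Compound 4, `O=C(OC1CCC(CN2CCN(c3cc(=O)c4cc(C(F)(F)F)cc([N+](=O)[O-])c4s3)CC2)CC1)c1ccncc1`, is not yet measured. It differs from compound 3 by pyridin-4-yl in place of 4-methoxyphenyl on a carbonyl carbon. Among the compounds with values here, the one measured step at the same place, a 1.7-fold higher number from compound 1 to compound 3 (0.23 log units; within the scatter), exchanged cyclohexyl for 4-methoxyphenyl on the carbonyl carbon and stayed within the scatter. The change to pyridin-4-yl is expected to behave alike, giving a step of a 1.1-fold lower number from compound 3 to compound 4 (0.04 log units; within the scatter) that is not expected to exceed the scatter. For compound 4 in this assay the estimate is 0.15 h, with a range from 0.06 h to 0.4 h.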

Compound 4, half-life: 0.075 h
Compound 4: middle estimate off by 2.0-fold (0.30 log units), on the high side, within the range that was stated.
By their numbers in this assay, from the lowest: compounds 4, 1 and 3 (each within the scatter of the next, the first and the last beyond it). At a limit, above all of these: compound 2.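

In this assay, within the data shown here, the group on the carbonyl carbon now proves able to move the half-life: a 2.2-fold lower number from compound 3 to compound 4 (0.34 log units; beyond the scatter) is the first step at this place beyond the scatter, whereas the exchange of cyclohexyl for 4-methoxyphenyl stayed within it. The separation holds only between 4-methoxyphenyl and pyridin-4-yl, since a 1.3-fold lower number from compound 1 to compound 4 (0.11 log units; within the scatter) stays within the scatter and cyclohexyl cannot be ordered against pyridin-4-yl. The exchange on the saturated ring carbon remains the far larger change, and with an at least 20-fold lower number from compound 2 to compound 4 (1.31 log units; beyond the scatter) the pyridin-4-yl compound joins compound 1 and compound 3 well below compound 2, so no group tried on the carbonyl carbon closes that gap.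

Open, from the compounds shown here alone, is whether a plain amide in place of the oxygen on the saturated ring carbon, or an amine or a carboxylic acid on the aromatic ring of the carbonyl group, would sit with the three carbonyl-bearing compounds or with compound 2. Going by these compounds, how large the gap to compound 2 truly is also stays open, as its result is a limit and not a number: the limit of > 1.55 h in this assay, at which 1 of the 4 values shown sits.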